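A few compounds are considered here, and "the series" means these few. Any claim that something is new, unique, unknown or untested is made for them only; others in the source may bear on it.

Measured so far in an assay on isolated protein for binding affinity to Equilibrative nucleoside transporter 1 (Homo sapiens); on this read-out lower numbers stand for stronger inhibition and higher numbers for weaker inhibition:
Compound 1 `Nc1nc(SCc2cccc(Br)c2)c2ncn([C@@H]3O[C@H](CO)[C@@H](O)[C@H]3O)c2n1` gives 2880 nM.
Compound 2 `Cc1cccc(CSc2nc(N)nc3c2ncn3[C@@H]2O[C@H](CO)[C@@H](O)[C@H]2O)n1` gives 11500000 nM.
Compound 3 `Nc1nc(SCc2ccccc2[N+](=O)[O-])c2ncn([C@@H]3O[C@H](CO)[C@@H](O)[C@H]3O)c2n1` gives 4570 nM.

Compound 3 stands second highest of the three numbers: its nearest neighbour is compound 1, with a 1.6-fold higher number from compound 1 to compound 3 (0.20 log units; within the scatter), and its furthest is compound 2, with a 2500-fold lower number from compound 2 to compound 3 (3.40 log units; beyond the scatter). Compound 4 `Nc1nc(SCCc2ccccc2)c2ncn([C@@H]3O[C@H](CO)[C@@H](O)[C@H]3O)c2n1` has not yet been measured. It differs from compound 3 by benzyl in place of 2-nitrophenyl on a saturated chain carbon bound to a sulfur. Two of the measured steps bear on this change. The swap between two carbocyclic aryl groups, a 1.6-fold higher number from compound 1 to compound 3 (0.20 log units; within the scatter), was within the scatter, whereas both steps involving the 6-methylpyridin-2-yl group, a 4000-fold higher number from compound 1 to compound 2 (3.60 log units; beyond the scatter) and a 2500-fold lower number from compound 2 to compound 3 (3.40 log units; beyond the scatter), were large. Since compound 4 keeps a carbon-only aromatic ring, the step is expected to resemble a 1.6-fold higher number from compound 1 to compound 3 (0.20 log units; within the scatter), so no change beyond the scatter is expected in this assay. Compound 4 is therefore estimated at 4000 nM, between 1500 nM and 12000 nM, meaning a 1.1-fold lower number from compound 3 to compound 4 (0.06 log units; within the scatter).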

Compound 4, half-maximal inhibitory concentration: 16200 nM
The estimate for compound 4 lay 4.1-fold (0.61 log units) below the measured number; measured number outside the range, above it.
By their numbers in this assay, from the lowest: compounds 1 and 3 (each within the scatter of the next); then compound 4; then compound 2.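

In this assay, a carbon-only aromatic ring at this position did not by itself keep the number within the scatter: benzyl on the saturated chain carbon bound to a sulfur gave a 3.5-fold higher number from compound 3 to compound 4 (0.55 log units; beyond the scatter) and, against 3-bromophenyl, a 5.6-fold higher number from compound 1 to compound 4 (0.75 log units; beyond the scatter). These modest steps remain far smaller than the one separating it from the 6-methylpyridin-2-yl group (a 710-fold lower number from compound 2 to compound 4 (2.85 log units; beyond the scatter)). No available evidence accounts for these differences.

The change removes the nitro group and extends the chain at once, so the compounds shown cannot separate the two. An unsubstituted phenyl on the same chain carbon, or a longer chain such as 3-phenylpropyl, would bear on that question.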